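The source may report more compounds than this note shows. Statements on the series, on what has been measured and on what is new or still open speak of the compounds shown alone.

Compound 2 `CN(C)CCCNc1nc2cc([N+](=O)[O-])ccc2nc1NCc1ccccc1C(F)(F)F` and compound 1 `CN1CCN(c2nc3cc([N+](=O)[O-])ccc3nc2NCc2ccc(C(F)(F)F)cc2)CC1` share a common core. In an ADME assay on HEK293 cells (Homo sapiens) for cytotoxicity, read by MTT assay, with a stated time of 24 h (on this read-out higher numbers stand for weaker inhibition and lower numbers for stronger inhibition), compound 2 gives 24.7 ug/mL, the higher of the two numbers, while compound 1 gives 6.99 ug/mL, and the gap between them lies beyond the usual scatter. Compound 3 `CN(C)CCCNc1nc2cc([N+](=O)[O-])ccc2nc1NCc1cc(F)cc(C(F)(F)F)c1` differs from compound 2 in a single place: 3-fluoro-5-(trifluoromethyl)phenyl in place of 2-(trifluoromethyl)phenyl on a saturated chain carbon bound to a nitrogen on an aromatic ring. Within the data shown here, no measured pair shows this change, so its effect in this assay is unknown. The step is expected to be small, within the scatter, in no clear direction. Compound 3 is therefore estimated at 20 ug/mL, with a range from 8 ug/mL to 50 ug/mL. The expected step is a 1.2-fold lower number from compound 2 to compound 3 (0.09 log units; within the scatter).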

Compound 3, half-maximal inhibitory concentration: 2.67 ug/mL
The estimate for compound 3 lay 7.5-fold (0.87 log units) above the measured number; the measured number lies below the stated range.
By their numbers in this assay, from the lowest: compound 3; then compound 1; then compound 2.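

Among these compounds, compound 2 and compound 3 give the first measured reading of this change. In this assay, 3-fluoro-5-(trifluoromethyl)phenyl in place of 2-(trifluoromethyl)phenyl on a saturated chain carbon bound to a nitrogen on an aromatic ring brings a 9.3-fold lower number from compound 2 to compound 3 (0.97 log units; beyond the scatter), so the read-out responds to the substitution of this ring. No measured evidence accounts for the step. The compounds shown do not separate the added fluorine from the changed place of the trifluoromethyl group. They also leave open how a phenyl ring carrying a nitrile or a methoxy group would read here.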